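A ring-bearing group in place of bromo on the shared core

The compounds below may be only part of what the source reports. "The series", "measured", "known", "first", "only" and "open" are said of these compounds alone.

Compound 3 `Cc1nc2c(OCc3ccccc3)cccn2c1Br` gives 26% in a functional assay on the whole organism with Rattus norvegicus as the target, with a stated time of 4 h, at a dose of 40 mg/kg by the intraperitoneal route (on this read-out higher numbers stand for more inhibition at the one dose given (going by the name of the read-out) and lower numbers for less inhibition), and stands second highest of the three numbers measured there: compound 1 `Cc1nc2c(OCc3ccccc3)cccn2c1C#N` gives 25%, within the scatter of compound 3, and compound 2 `CCSCc1c(C)nc2c(OCc3ccccc3)cccn12` gives 36%, also within the scatter of compound 3. Compound 4 `Cc1nc2c(OCc3ccccc3)cccn2c1CC1=NCCN1` differs from compound 3 by a group of 6 heavy atoms (4 carbon, 2 nitrogen; one five-membered non-aromatic ring with 2 hetero atoms) in place of one bromine atom, on an aromatic carbon. The steps touching the same aromatic carbon were a number 1 percentage points higher from compound 1 to compound 3 (within the scatter) and a number 10 percentage points lower from compound 2 to compound 3 (within the scatter); neither passed beyond the scatter, while a number 11 percentage points higher from compound 1 to compound 2 (beyond the scatter) did. With such small moves among three different groups at this carbon, no step beyond the scatter is expected for compound 4 in this assay, and a number 6 percentage points higher from compound 3 to compound 4 (within the scatter) is the estimated change. Compound 4 is therefore expected to give about 32%, between 15% and 50%.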

Compound 4, a percentage reported as inhibition, in the whole organism at one dose (the size of the read-out at that dose, not a potency): 69%
Beside the measured number, compound 4's estimate is 37 percentage points below it; the whole stated range lies below it.
By their numbers in this assay, from the lowest: compounds 1, 3 and 2 (each within the scatter of the next, the first and the last beyond it); then compound 4.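

In this assay, within the data shown here, the group with the five-membered non-aromatic ring is the only one of the four at this aromatic carbon to move the number so far, with a number 43 percentage points higher from compound 3 to compound 4 (beyond the scatter) and a number 44 percentage points higher from compound 1 to compound 4 (beyond the scatter) as well as a number 33 percentage points higher from compound 2 to compound 4 (beyond the scatter) on the same shared core. Bromo, cyano and (ethylsulfanyl)methyl differed from one another far less, so this position is not indifferent to what it carries. Nothing given here accounts for the gain. The compounds shown leave open whether the ring is needed at all, or whether a simple open-chain amine on the same saturated chain carbon would do as much. They also leave open how a longer chain between the ring and the aromatic carbon would read.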